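From 4-nitrophenyl to 3-chlorophenyl: notes on compound 4

This account rests on a few compounds, and the source may have more. Where it says the series, first, only, none or still open, it means among the compounds named here.

Of the compounds shown here, three have been measured so far in a functional assay on MCF7 cells (Homo sapiens) for cytotoxicity, read by MTT assay, with a stated time of 72 h; on this read-out lower numbers stand for stronger inhibition and higher numbers for weaker inhibition. Compound 1 (`CNC(=O)c1cc(Oc2ccc(NC(=O)c3cc(-c4ccc(Cl)cc4)ncn3)cc2F)ccn1`) gives only a limit, > 100000 nM. Compound 2 (`CNC(=O)c1cc(Oc2ccc(NC(=O)c3nccc(-c4ccccc4)n3)cc2)ccn1`) gives a number, 39100 nM. Compound 3 (`CNC(=O)c1cc(Oc2ccc(NC(=O)c3nccc(-c4ccc([N+](=O)[O-])cc4)n3)cc2)ccn1`) also gives only a limit, > 100000 nM. Compound 3 therefore has no number of its own and stands at the limit of > 100000 nM in this assay, at which 2 of the 3 values shown sit.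

Compound 4 (`CNC(=O)c1cc(Oc2ccc(NC(=O)c3nccc(-c4cccc(Cl)c4)n3)cc2)ccn1`) takes 3-chlorophenyl in place of 4-nitrophenyl on an aromatic carbon. Going by the values given here, the one measured step that bears on this change is an at least 2.5-fold higher number from compound 2 to compound 3 (0.40 log units; beyond the scatter), with nitro in place of hydrogen on an aromatic carbon. Compound 4 carries no nitro, so that step, read in reverse, points to a modest move toward lower numbers. Among the compounds with values here, no measured step covers the 3-chlorophenyl group itself, and the starting point is a limit, so the size of the move stays uncertain and the range is kept wide. The expected step in this assay is an at least 2.5-fold lower number from compound 3 to compound 4 (0.39 log units; beyond the scatter). Compound 4 is estimated at 40000 nM, with an expected range of 14000 nM to 90000 nM.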

Compound 4, half-maximal inhibitory concentration: > 100000 nM
Compound 4: a limit, no number; the forecaster's own chance of this, stated with the estimate: 35%; middle value at least 2.5-fold (0.39 log units) from the limit.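

In this assay, 3-chlorophenyl at this position, on an aromatic carbon of the six-membered aromatic ring with 2 nitrogen, shows that dropping the nitro does not bring back a measurable value: chloro in place of hydrogen on the phenyl gives an at least 2.5-fold higher number from compound 2 to compound 4 (0.40 log units; beyond the scatter). Together with an at least 2.5-fold higher number from compound 2 to compound 3 (0.40 log units; beyond the scatter), this means two different substituents on the phenyl, at different places on it, each move the value away from compound 2, whose unsubstituted phenyl gives the only number among these compounds with this core. Compound 3 and compound 4 are both limits, so the step between them cannot be read and neither group can be ranked against the other, as both stop at the same ceiling: the limit of > 100000 nM in this assay, at which 3 of the 4 values shown sit.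

Going by these compounds, how far above that ceiling either compound lies stays open, and so does whether the chloro would act the same at another place on the phenyl. Also open, on these data alone, is whether an amine, a methoxy group or a carboxylic acid on that phenyl would stay close to compound 2 or also reach the limit.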